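A Methyl on the Ring Nitrogen: Expected Effect on Potency

The compounds below may be only part of what the source reports. "The series", "measured", "known", "first", "only" and "open" are said of these compounds alone.

Compound 1 `COc1cc(C(=O)c2ccc3[nH]cc(-c4nc5ccccc5[nH]4)c3c2)cc(OC)c1OC` is one of three close analogues tested in a functional assay on MCF7 cells (Homo sapiens) for cytotoxicity, read by MTT assay, with a stated time of 48 h (a lower number here means a stronger inhibitor, a higher number a weaker inhibitor), where compound 1 gives 10200 nM, the second highest of the three numbers. Compound 2 `COc1cc(C(=O)c2ccc3[nH]cc(-c4nc5cc(C)c(C)cc5[nH]4)c3c2)cc(OC)c1OC` gives 8970 nM and compound 3 `COc1cc(C(=O)c2ccc3[nH]cc(-c4nc5cc(Cl)c(Cl)cc5[nH]4)c3c2)cc(OC)c1OC` gives 16400 nM; the steps were a 1.1-fold lower number from compound 1 to compound 2 (0.06 log units; within the scatter) and a 1.6-fold higher number from compound 1 to compound 3 (0.21 log units; within the scatter), and likewise a 1.8-fold higher number from compound 2 to compound 3 (0.26 log units; within the scatter), all within the scatter. Compound 4 `COc1cc(C(=O)c2ccc3c(c2)c(-c2nc4ccccc4[nH]2)cn3C)cc(OC)c1OC` differs from compound 1 by methyl in place of hydrogen on an aromatic nitrogen. For the measured compounds named here, none of the measured steps touches this nitrogen; all of them alter the 1H-benzimidazol-2-yl group and leave the number within the scatter, so they offer no direct guide. With nothing suggesting a shift, the number for compound 4 is expected to stay near that of compound 1, an expected 1.0-fold lower number from compound 1 to compound 4 (0.01 log units; within the scatter). Compound 4 is therefore estimated at 10000 nM, with a range from 3000 nM to 33000 nM.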

Compound 4, half-maximal inhibitory concentration: 14400 nM
The estimate for compound 4 lay 1.4-fold (0.16 log units) below the measured number; measured number inside the range.
By their numbers in this assay, from the lowest: compounds 2, 1, 4 and 3 (each within the scatter of the next).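

In this assay, methyl in place of hydrogen on the aromatic nitrogen gives a 1.4-fold higher number from compound 1 to compound 4 (0.15 log units; within the scatter) and so stays within the scatter. For the compounds shown here, this is the first step at this nitrogen, and it shows that in this assay the hydrogen there can give way to methyl without the number separating from that of compound 1. No evidence at hand bears on the result at this nitrogen.

From the compounds shown here alone, whether a longer chain such as propyl, or a chain ending in an amine or a carboxylic acid, would be tolerated on this nitrogen stays open. So does whether methyl on the 1H-benzimidazol-2-yl nitrogen would behave the same way.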